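The compounds below may be only part of what the source reports. "The series", "measured", "known", "first", "only" and "open" are said of these compounds alone.

Measured so far in an in vitro ADME assay on microsomes from liver (Homo sapiens) for metabolic stability; on this read-out higher numbers stand for fast clearance and lower numbers for slow clearance:

compound 1 `Cc1ccc(NC(=O)[C@H](CC2CCCC2)n2cnc(C(F)(F)F)c2)nc1` gives > 120 mL/min/kg
compound 2 `O=C(O)c1ccc(NC(=O)[C@H](CC2CCCC2)n2cnc(C(F)(F)F)c2)nc1` gives < 8 mL/min/kg
compound 3 `O=C(O)c1cccc(NC(=O)[C@H](CC2CCCC2)n2cnc(C(F)(F)F)c2)n1` gives < 8 mL/min/kg

All three entries are limits of the assay, not numbers. Compound 3 stands at the limit of < 8 mL/min/kg in this assay, at which 2 of the 3 values shown sit, shared with compound 2, while compound 1 alone stands at the limit of > 120 mL/min/kg in this assay, at which 1 of the 3 values shown sits. The next compound is compound 4 `O=C(O)c1ccnc(NC(=O)[C@H](CC2CCCC2)n2cnc(C(F)(F)F)c2)c1`, which has 4-carboxypyridin-2-yl in place of 6-carboxypyridin-2-yl on an amide-type nitrogen.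

Two measured steps show what a carboxy group has gone with in this short series: an at least 15-fold lower number from compound 1 to compound 2 (1.17 log units; beyond the scatter) and an at least 15-fold lower number from compound 1 to compound 3 (1.17 log units; beyond the scatter). Both are large and beyond the scatter. For the measured compounds named here, the closest precedent is a step that the two limits leave unreadable from compound 2 to compound 3, which also replaces one carboxypyridinyl group with another, but its size cannot be read. Compound 4 keeps the carboxy group, so with an at least 15-fold lower number from compound 1 to compound 3 (1.17 log units; beyond the scatter) in view it is expected to remain on the slow-clearance side of this assay, with no step beyond the scatter and probably another limit. The expected step is a step that the limit leaves unreadable from compound 3 to compound 4. For compound 4 the estimated value is 7 mL/min/kg. The expected range for compound 4 runs from 4 mL/min/kg to 14 mL/min/kg.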

Compound 4, clearance: < 8 mL/min/kg
Compound 4 was reported as a limit (the forecaster's own chance of this, stated with the estimate: 80%); the middle value does not contradict the limit.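

In this assay compound 4 is reported as a limit and not a number, and it joins the slow-clearance end of the read-out: the limit of < 8 mL/min/kg in this assay, at which 3 of the 4 values shown sit. The 4-carboxypyridin-2-yl group on the amide-type nitrogen keeps the large gap to the 5-methylpyridin-2-yl group, with an at least 15-fold lower number from compound 1 to compound 4 (1.17 log units; beyond the scatter), so three placements of the carboxy group now fall on the same side of that gap, and no carboxy compound shown goes against this. The steps among compound 2, compound 3 and compound 4 cannot be read, as each has a limit at both ends, and the three carboxy placements therefore cannot be ranked.

On these data alone, whether the placements differ in clearance stays open, since any difference would lie past the limit of this read-out. Also open, as far as these compounds go, is whether the free carboxylic acid is needed for the result, or whether a primary amide, a methyl ester or a hydroxymethyl group on the same pyridin-2-yl ring would give a value between the two limits and so allow a readable step.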